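Removing the chloro group from a nitro-bearing flavone

The compounds below may be only part of what the source reports. "The series", "measured", "known", "first", "only" and "open" are said of these compounds alone.

For the measured compounds named here, compound 1 `O=c1cc(-c2ccc(Cl)c([N+](=O)[O-])c2)oc2ccccc12` gives 50700 nM in a functional assay on MOLT-4 cells (Homo sapiens) for cytotoxicity, read by sulforhodamine B assay, with a stated time of 48 h (a higher number here means a weaker inhibitor of growth, a lower number a stronger inhibitor of growth), the only measured number in the set. Compound 2 `COc1cc(OC)cc(-c2cc(=O)c3ccccc3o2)c1` is reported in this assay as < 100 nM, which is a limit of the assay rather than a number. Compound 3 `O=c1cc(-c2cccc([N+](=O)[O-])c2)oc2ccccc12` differs from compound 1 by hydrogen in place of chloro on an aromatic carbon. Going by the values given here, no step between two measured compounds is available, so the direction is unknown; little movement beyond the scatter in this assay is expected from compound 1 to compound 3, a 1.3-fold lower number from compound 1 to compound 3 (0.10 log units; within the scatter). For compound 3 the expected value in this assay is 40000 nM, estimated between 10000 nM and 150000 nM.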

Compound 3, concentration for 50% growth inhibition: 36000 nM
Compound 3: middle estimate off by 1.1-fold (0.05 log units), on the high side; measured number inside the range.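

On the aromatic carbon ortho to a nitro group, hydrogen in place of chloro gives a 1.4-fold lower number from compound 1 to compound 3 (0.15 log units; within the scatter) in this assay and so the two compounds cannot be told apart. The chloro group can therefore be lost at this position without a readable shift in this measurement, at least while the nitro group stays in place. Going by these compounds, whether an amine or a carboxylic acid at this position, or the same loss of the chloro group without the nitro group, would read differently stays open. The compounds shown also give no reason for this result.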